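A few compounds are considered here, and "the series" means these few. Any claim that something is new, unique, unknown or untested is made for them only; others in the source may bear on it.

In an ADME assay on Huh-7 cells (Homo sapiens) for cytotoxicity (on this read-out higher numbers stand for lower toxicity in this test and lower numbers for higher toxicity in this test), the measured compounds are compound 1 `Cc1ccccc1-c1nn(-c2ccc(Cl)cc2)cc1CNCCN1CCN(C)CC1` with 17000 nM and compound 2 `CCCN1CCC(CNCc2cn(-c3ccc([N+](=O)[O-])cc3)nc2-c2ccc(OC(F)(F)F)cc2)CC1` with 18000 nM. Compound 3 `COc1ccc(-c2nn(-c3ccc(F)cc3F)cc2CNCCN2CCN(C)CC2)cc1` gives > 20000 nM, which is a limit of the assay and not a number.

Compound 1 stands at the lowest of the two numbers shown, and compound 2 lies within the scatter of it, so the two are not told apart. The third value is the limit of > 20000 nM in this assay, at which 1 of the 3 values shown sits, belonging to compound 3.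

Compound 4 `CCOC(=O)Cn1cc(CNCCN2CCN(C)CC2)c(-c2ccccc2C)n1` has not yet been measured. It differs from compound 1 in one place: (ethoxycarbonyl)methyl in place of 4-chlorophenyl on an aromatic nitrogen. Within the data shown here, no step between measured compounds bears on this change. All three measured values lie close together, and the step of a 1.2-fold higher number from compound 1 to compound 4 (0.07 log units; within the scatter) is expected to be none beyond the scatter. For compound 4 the expected value is 20000 nM, between 8000 nM and 50000 nM.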

Compound 4, half-maximal cytotoxic concentration: > 20000 nM
Compound 4: only a limit was reported; the forecaster's own chance of this, stated with the estimate: 40%; the middle value lies on the limit itself.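

Replacing the aromatic ring on this nitrogen gives, in this assay, an at least 1.1-fold higher number from compound 1 to compound 4 (0.07 log units; that floor lies within the scatter), a step that rests on a limit of the assay and not on a number. For this one pair, (ethoxycarbonyl)methyl in place of 4-chlorophenyl brings no lower number, so the carbon-only aromatic ring is not required at this position to keep the number this high. The result adds to the values at the top of the range: the limit of > 20000 nM in this assay, at which 2 of the 4 values shown sit.

On these data alone, how far compound 4 lies beyond the limit stays open, so the full size of the step cannot be read. As far as these compounds go, whether a carboxylic acid or a primary amide in place of the ethyl ester would behave the same on this nitrogen also stays open.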